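Aryl sulfonyl quinoline series: chloro for fluoro on sulfonyl aryl

This account rests on a few compounds, and the source may have more. Where it says the series, first, only, none or still open, it means among the compounds named here.

Measured so far:
- compound 1, `O=S(=O)(c1ccc(F)cc1)c1cnc2ccc(Cl)cc2c1-c1ccc(Cl)cc1`: "not determined" (no result reported) in an assay (strain Sprague-Dawley) for displacement of a labelled ligand from metabotropic glutamate receptor 5 (Rattus norvegicus), with a stated time of 60 min; on this read-out lower numbers stand for stronger inhibition and higher numbers for weaker inhibition
- compound 2, `O=S(=O)(c1ccc(F)c(F)c1)c1cnc2cc(F)ccc2c1-c1ccc(Cl)cc1`: 17.1 nM
- compound 3, `O=S(=O)(c1ccc(F)cc1)c1cnc2cc(F)c(Cl)cc2c1-c1ccc(Cl)cc1`: "not determined" (no result reported) in this assay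

Going by the values given here, compound 1 and compound 3 carry no number in this assay, so compound 2 is the only compound of the three with a measured inhibition constant; there is nothing here to rank it against, and no step between measured compounds can be drawn.

Compound 4, `O=S(=O)(c1ccc(F)c(Cl)c1)c1cnc2cc(F)ccc2c1-c1ccc(Cl)cc1`, is the next compound to be measured. It differs from compound 2 in one place: chloro in place of fluoro on an aromatic carbon. The change sits on the aromatic carbon of a six-membered aromatic ring of carbon only, ortho to a fluoro group and meta to a large group, so the 3,4-difluorophenyl of compound 2 becomes a 3-chloro-4-fluorophenyl.

With no measured step of this kind in the series, the expectation rests on the size of the change alone: one heavy atom exchanged for one heavy atom, with no change in donors, acceptors or charge. The expected step from compound 2 to compound 4 in this assay is a 1.1-fold lower number from compound 2 to compound 4 (0.06 log units; within the scatter), that is, no shift beyond the usual scatter of repeated measurements. Compound 4 is therefore estimated at 15 nM, within a range of 5 nM to 45 nM.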

Compound 4, inhibition constant: 8.3 nM
For compound 4 the middle estimate is 1.8-fold (0.26 log units) above the measured one; low and high end bracket the measured number.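

In this assay, a 2.1-fold lower number from compound 2 to compound 4 (0.31 log units; beyond the scatter) gives the series its first step between measured compounds, and it places a modest change beyond the usual scatter at a single aromatic carbon. At this carbon, ortho to a fluoro group and meta to a large group, chloro is accepted in place of fluoro without loss of affinity, and the 3-chloro-4-fluorophenyl of compound 4 reads as the stronger of the two aryl groups in this pair. This finding rests on one pair with a single shared core and a single fluoro group left in place, and no measurement available here bears on the reason for the step.

Still open, going by these compounds, is whether the trend continues beyond chloro at this carbon, as bromo, methyl, methoxy, or a polar group such as an amine or a carboxylic acid would each test. Also open, on these data alone, is whether the same exchange of fluoro for chloro gives a step of similar size when the other substituents on the shared core differ from those of compound 2.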